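This account rests on a few compounds, and the source may have more. Where it says the series, first, only, none or still open, it means among the compounds named here.

Working notes on the series. Two members have been run in a functional assay on HBL-100 cells (Homo sapiens) for inhibition, read by sulforhodamine B assay, with a stated time of 48 h (on this read-out lower numbers stand for stronger inhibition of growth and higher numbers for weaker inhibition of growth), so far. Compound 1 `CC(=O)OC/C(=C/c1ccccc1[N+](=O)[O-])C(=O)c1ccccc1` returns only a limit of the assay, > 100000 nM, and no number. For the measured compounds named here, compound 2 `O=C(OC/C(=C/c1ccc(Cl)cc1Cl)C(=O)c1ccccc1)c1ccccc1` gives 26000 nM in this assay and so stands as the only plain number in the set. The other entry, that of compound 1, is a limit: the limit of > 100000 nM in this assay, at which 1 of the 2 values shown sits.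

Compound 3 `O=C(OC/C(=C/c1ccccc1[N+](=O)[O-])C(=O)c1ccccc1)c1ccccc1` is not yet measured. It differs from compound 2 in one place: 2-nitrophenyl in place of 2,4-dichlorophenyl on a double-bonded chain carbon bound to a double-bonded chain carbon. Going by the values given here, no measured pair in this set differs in just one place, so no step size can be read off the numbers.

The expectation for the change from compound 2 to compound 3 in this assay is a loss of growth inhibition, a 2.3-fold higher number from compound 2 to compound 3 (0.36 log units; beyond the scatter), somewhat beyond the scatter, leaning that way because the limit of > 100000 nM in this assay, at which 1 of the 2 values shown sits, shows one of the two values already sitting at the limit. Compound 3 is thus estimated at 60000 nM in this assay, with a range from 25000 nM to 150000 nM, and a fair chance that only a limit is returned.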

Compound 3, concentration for 50% growth inhibition: > 100000 nM
Compound 3 was reported as a limit (the forecaster's own chance of this, stated with the estimate: 40%); middle value at least 1.6-fold (0.22 log units) away from the limit.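

In this assay, for the compounds shown here, 2-nitrophenyl in place of 2,4-dichlorophenyl on a double-bonded chain carbon bound to a double-bonded chain carbon gives an at least 3.8-fold higher number from compound 2 to compound 3 (0.58 log units; beyond the scatter), the first step that can be read and the first sign that growth inhibition at this position depends on the aryl group. Compound 3 is recorded only as a limit, so this size is a minimum and not a measured gap. The change of phenyl in place of methyl on a carbonyl carbon, which links compound 1 and compound 3, cannot be read, because both compounds stand at a limit and most of the set gives no plain number: the limit of > 100000 nM in this assay, at which 2 of the 3 values shown sit.

The compounds shown leave open whether the loss follows from the entry of the nitro group or from the departure of the two chlorines, a question that a plain phenyl, a 4-chlorophenyl or a 2-aminophenyl at this place would address. Also open, going by these compounds, is how phenyl and methyl on the carbonyl carbon compare when 2,4-dichlorophenyl is kept, and whether a longer chain there would change the picture.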